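Adding a methyl to the hydroxyalkyl chain of compound 1

A few compounds are considered here, and "the series" means these few. Any claim that something is new, unique, unknown or untested is made for them only; others in the source may bear on it.

Among the measured compounds shown here, in a functional assay on MCF7 cells (Homo sapiens) for inhibition, with a stated time of 96 h (on this read-out higher numbers stand for weaker inhibition and lower numbers for stronger inhibition), compound 1 (`C[C@H](CO)Nc1nc(Nc2ccc([S+](N)[O-])cc2)ncc1Br`) gives 266 nM and holds the higher of the two numbers so far. Compound 2 (`C[C@@H](O)[C@@H](C)Oc1nc(Nc2ccc(S(=N)(=O)C3CC3)cc2)ncc1C(F)(F)F`) gives 15 nM in this assay, a gap beyond the scatter. For the measured compounds named here, no two measured compounds differ in only one place, so the data do not yet show the size of any single change.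

Compound 3 (`C[C@@H](O)[C@@H](C)Nc1nc(Nc2ccc([S+](N)[O-])cc2)ncc1Br`) is the next to be read in this assay. It departs from compound 1 by one change: methyl in place of hydrogen on a saturated chain carbon bound to an oxygen on a saturated carbon and a saturated chain carbon. This turns (1-(hydroxymethyl)ethyl)amino into (2-hydroxy-1-methylpropyl)amino.

Going by the values given here, the only lower number in hand, compound 2 at 15 nM, tilts the expectation toward stronger inhibition, though this is thin support. The expected move is modest and toward a lower number, an estimated 2.7-fold lower number from compound 1 to compound 3 (0.42 log units; beyond the scatter) in this assay. For compound 3 the estimate is 100 nM (expected range 30 nM to 330 nM).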

Compound 3, half-maximal inhibitory concentration: 30 nM
Beside the measured number, compound 3's estimate is 3.3-fold (0.52 log units) above it; low and high end bracket the measured number.
By their numbers in this assay, from the lowest: compounds 2 and 3 (each within the scatter of the next); then compound 1.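

Among the compounds shown here, the step of an 8.9-fold lower number from compound 1 to compound 3 (0.95 log units; beyond the scatter) in this assay is the first comparison that isolates a single change: methyl in place of hydrogen on a saturated chain carbon bound to an oxygen on a saturated carbon and a saturated chain carbon. It shows that this position responds to substitution, since going from (1-(hydroxymethyl)ethyl)amino to (2-hydroxy-1-methylpropyl)amino, with the rest of the structure held constant, moves the number beyond the scatter, and the size of the step is rated modest. No available data bear on the reason for this step.

As far as these compounds go, what remains open is whether the trend continues with a larger group at this carbon, such as ethyl or a longer chain, or whether the methyl is a single favourable case, and whether the hydroxyl on this carbon can give way to an amine or a methoxy group. Compound 2 differs from compound 3 in more than one place, so this pair cannot show whether the same methyl step would hold with the other groups found in compound 2.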